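The source may hold more compounds than are shown below. What is called first, only, known or untested is meant among the compounds shown, and "the series" means these compounds.

Working notes on a small set built on the shared core of compound 1 `COc1cc(-c2ccccc2)cc(O)c1O`. In a functional assay on A549 cells (Homo sapiens) for cytotoxicity, read by sulforhodamine B assay (on this read-out lower numbers stand for stronger inhibition and higher numbers for weaker inhibition), compound 1 gives only a limit, > 10000 nM. Compound 2 `COc1cc(-c2ccccc2)cc(OC)c1OC` likewise gives only a limit in this assay, namely > 10000 nM. For the measured compounds named here, compound 2 thus stands at the limit of > 10000 nM in this assay, at which 2 of the 2 values shown sit, with no number that would set it apart from compound 1, and no measured step exists between the two. Compound 3 `COc1cc(-c2ccccc2)cc(OC)c1O` has not yet been tested in this assay. Its difference from compound 2 is hydrogen in place of methyl on an oxygen on an aromatic ring. The step from compound 2 to compound 3 in this assay is expected to be none beyond the scatter, most likely again a limit rather than a number. The estimate for compound 3 in this assay is 20000 nM, with a range of 8000 nM to 60000 nM. The expected step is a step that the limit leaves unreadable from compound 2 to compound 3.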

Compound 3, half-maximal inhibitory concentration: > 10000 nM
Compound 3 gave a limit, no number (the forecaster's own chance of this, stated with the estimate: 85%); the middle value lies beyond the limit too.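

Compound 3 also gives only a limit in this assay, so no step can be read among compound 1, compound 2 and compound 3: the limit of > 10000 nM in this assay, at which 3 of the 3 values shown sit.

The compounds shown leave open which change to the shared core, if any, would give a measurable value in this assay.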